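A Third Group on the Amide Nitrogen

A few compounds are considered here, and "the series" means these few. Any claim that something is new, unique, unknown or untested is made for them only; others in the source may bear on it.

Among the compounds with values here, in a functional assay on Jurkat cells (Homo sapiens) (on this read-out higher numbers stand for weaker inhibition and lower numbers for stronger inhibition), compound 1 (`C[C@H](NC(=O)C(=O)NCC1CCCCC1)C(=O)N[C@@H](CC(=O)O)C(=O)COc1c(F)c(F)cc(F)c1F`) gives 19 nM and compound 2 (`C[C@H](NC(=O)C(=O)Nc1cccnc1N(C)C)C(=O)N[C@@H](CC(=O)O)C(=O)COc1c(F)c(F)cc(F)c1F`) gives 27 nM, so compound 2 stands within the scatter of the only other measured value. Compound 3 (`C[C@H](NC(=O)C(=O)NCC1(c2ccccc2)CC1)C(=O)N[C@@H](CC(=O)O)C(=O)COc1c(F)c(F)cc(F)c1F`) carries (1-phenylcyclopropyl)methyl in place of 2-(dimethylamino)pyridin-3-yl on an amide-type nitrogen. Within the data shown here, the one measured change at this nitrogen, a 1.4-fold higher number from compound 1 to compound 2 (0.15 log units; within the scatter), stays within the scatter, so no shift beyond the scatter is expected in this assay, and no direction can be assigned. The expected change is a 1.2-fold lower number from compound 2 to compound 3 (0.09 log units; within the scatter). Compound 3 is estimated at 22 nM, with an expected range of 8 nM to 60 nM.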

Compound 3, half-maximal inhibitory concentration: 27 nM
Compound 3: middle estimate off by 1.2-fold (0.09 log units), on the low side; the measured number falls inside the stated range.
By their numbers in this assay, from the lowest: compounds 1, 2 and 3 (each within the scatter of the next).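

In this assay the swap of 2-(dimethylamino)pyridin-3-yl for (1-phenylcyclopropyl)methyl gives no change at the digits printed from compound 2 to compound 3 (within the scatter) and 1-phenylcyclopropyl in place of cyclohexyl gives a 1.4-fold higher number from compound 1 to compound 3 (0.15 log units; within the scatter) on the saturated chain carbon. This amide-type nitrogen thus carries three different groups, one with a three-membered carbon ring, and all three compounds lie within the scatter of one another. Nothing available explains this tolerance. The compounds shown leave open whether a group bearing a carboxylic acid or a primary amine, or a small methyl, would also stay within the scatter at this nitrogen.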